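From 4-ethoxyphenyl to 3,4-dimethylphenyl on a shared core

The compounds below may be only part of what the source reports. "The series", "measured", "known", "first", "only" and "open" are said of these compounds alone.

Compound 1 `COc1ccc(C(=O)Nc2c[nH]c(=O)c(-c3cccc(C)c3)c2)c(O)c1` gives > 100000 nM as a limit
Compound 2 `CCOc1ccc(-c2cc(NC(=O)c3ccc(OC)cc3O)c[nH]c2=O)cc1` gives 69600 nM as a number

For the measured compounds named here, in an ADME assay on HepG2 2.2.15 cells (Homo sapiens) for cytotoxicity, read by CCK-8 assay, with a stated time of 8 days (a lower number here means that less compound is tolerated, a higher number that more compound is tolerated), compound 2 gives 69600 nM as the only actual number so far. Compound 3 `COc1ccc(C(=O)Nc2c[nH]c(=O)c(-c3ccc(C)c(C)c3)c2)c(O)c1` has 3,4-dimethylphenyl in place of 4-ethoxyphenyl on an aromatic carbon of the shared core. Going by the values given here, one measured step bears on this change: an at least 1.4-fold lower number from compound 1 to compound 2 (0.15 log units; that floor lies within the scatter) at the same place. With a step of that size, no change beyond the scatter is expected in this assay here. Compound 3 is estimated at 85000 nM within an expected range from 40000 nM to 150000 nM in this reading. The expected move is a 1.2-fold higher number from compound 2 to compound 3 (0.09 log units; within the scatter) and no larger.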

Compound 3, half-maximal cytotoxic concentration: 31300 nM
For compound 3 the middle estimate is 2.7-fold (0.43 log units) above the measured one, outside the stated range (below it).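

In this assay, the group on this aromatic carbon of the shared core now shows a change beyond the scatter: 3,4-dimethylphenyl in place of 4-ethoxyphenyl gives a 2.2-fold lower number from compound 2 to compound 3 (0.35 log units; beyond the scatter). Methyl in place of hydrogen on an aromatic carbon gives an at least 3.1-fold lower number from compound 1 to compound 3 (0.50 log units; beyond the scatter). The value of compound 1 is a limit and not a number, so that step is only a floor: the limit of > 100000 nM in this assay, at which 1 of the 3 values shown sits.

Still open, on these data alone, is how an amine or a carboxylic acid on the phenyl group at this place would read in this assay. Also open, as far as these compounds go, is whether a longer chain than ethoxy would change the number.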